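The source may report more compounds than this note shows. Statements on the series, on what has been measured and on what is new or still open speak of the compounds shown alone.

Compound 3 `C/C=C/c1c(C)nn(CCCN2CCN(c3ccc(C)cc3)CC2)c(=O)c1N` stands highest of the three measured compounds in a functional assay on the whole organism (Abdomen, strain Swiss) for inhibition, with Mus musculus as the target, with stated times of 30 min, 10 min and 5 min, at a dose of 20 mg/kg by the oral route (a higher number here means a stronger effect of the compound at the dose given, a lower number a weaker effect), where compound 3 gives 44%. Compound 1 `CCCC(=O)c1c(C)nn(CCCN2CCN(c3ccc(C)cc3)CC2)c(=O)c1N` gives 25% in this assay, and compound 2 `CCCCC(=O)c1c(C)nn(CCCN2CCN(c3ccc(C)cc3)CC2)c(=O)c1N` gives 23%; the steps of a number 19 percentage points higher from compound 1 to compound 3 (beyond the scatter) and a number 21 percentage points higher from compound 2 to compound 3 (beyond the scatter) set both apart from compound 3.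

Compound 4 `CC/C=C/c1c(C)nn(CCCN2CCN(c3ccc(C)cc3)CC2)c(=O)c1N` has not been measured. Its change from compound 3 is methyl in place of hydrogen on a saturated chain carbon bound to a double-bonded chain carbon. Among the measured compounds shown here, the one measured step that resembles it is a number 2 percentage points lower from compound 1 to compound 2 (within the scatter), likewise a methyl added to a saturated chain carbon, and that step stayed within the scatter. For the measured compounds named here, no measured step speaks against carrying the read-out of compound 3 forward unchanged. A step of no size beyond the scatter, in no particular direction, is therefore expected in this assay. The expected step of no change at the digits printed from compound 3 to compound 4 (within the scatter) is accordingly taken as small. Compound 4 is estimated at 44% in this assay, with a range from 30% to 58%.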

Compound 4, a percentage reported as inhibition, in the whole organism at one dose (the size of the read-out at that dose, not a potency): 35%
Estimate against measurement, compound 4: 9 percentage points above; low and high end bracket the measured number.
By their numbers in this assay, from the lowest: compounds 2, 1, 4 and 3 (each within the scatter of the next, the first and the last beyond it).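

In this assay, methyl in place of hydrogen on the saturated chain carbon bound to a double-bonded chain carbon gives a number 9 percentage points lower from compound 3 to compound 4 (within the scatter), so this change, prop-1-en-1-yl to but-1-en-1-yl, produces no step beyond the scatter at this position. The same methyl addition now reads alike on two cores: the same change on two cores in this assay, a number 2 percentage points lower (within the scatter) from compound 1 to compound 2 and a number 9 percentage points lower (within the scatter) from compound 3 to compound 4, 7 percentage points apart, within the scatter of two such steps With but-1-en-1-yl, the separation from the carbonyl compounds is no longer uniform, with a number 12 percentage points higher from compound 2 to compound 4 (beyond the scatter) but a number 10 percentage points higher from compound 1 to compound 4 (within the scatter).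

As far as these compounds go, how a chain longer than but-1-en-1-yl, or a phenyl or a carboxylic acid at the end of this chain, would read remains open. The read-out at one dose gives the size of the effect at that dose, so the effect of these compounds at other doses also remains open.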